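Cyano in place of trifluoromethyl on the anilide ring

The source may report more compounds than this note shows. Statements on the series, on what has been measured and on what is new or still open speak of the compounds shown alone.

Going by the values given here, compound 2 `N#Cc1cc(F)cc(C(=O)Nc2cccc(C(F)(F)F)c2)c1` gives 543 nM in an in vitro functional assay on HEK293-A cells for antagonist activity at metabotropic glutamate receptor 5 (Rattus norvegicus), read by calcium flux (a lower number here means a stronger inhibitor, a higher number a weaker inhibitor), the lowest of the two numbers so far; compound 1 `N#Cc1cc(F)cc(C(=O)Nc2cccc(F)c2)c1` gives 2160 nM. Among the compounds with values here, the only measured step bearing on this ring is a 4.0-fold lower number from compound 1 to compound 2 (0.60 log units; beyond the scatter), a change from a smaller to a larger group. Compound 3 `N#Cc1cccc(NC(=O)c2cc(F)cc(C#N)c2)c1` carries cyano in place of trifluoromethyl on an aromatic carbon. Within the data shown here, no measured pair compares cyano with trifluoromethyl, so the direction is uncertain; a cyano group of intermediate size leaves the number between those of compound 1 and compound 2, or near compound 2. For compound 3 a step of a 1.3-fold higher number from compound 2 to compound 3 (0.11 log units; within the scatter) is expected, within the scatter. Compound 3 is estimated at 700 nM, range 200 nM to 2500 nM.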

Compound 3, half-maximal inhibitory concentration: 489 nM
Estimate against measurement, compound 3: 1.4-fold (0.16 log units) above; the range from low to high includes it.
By their numbers in this assay, from the lowest: compounds 3 and 2 (each within the scatter of the next); then compound 1.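

In this assay, the step of a 1.1-fold lower number from compound 2 to compound 3 (0.05 log units; within the scatter) shows that cyano and trifluoromethyl cannot be told apart at this position on the anilide ring. The step of a 4.4-fold lower number from compound 1 to compound 3 (0.65 log units; beyond the scatter) shows that cyano, like trifluoromethyl, gives a lower number than fluoro, so among these three compounds the gain does not require the group with the most heavy atoms. No supporting measurement is available to explain this match. Open, going by these compounds, is whether an amine, a carboxylic acid or a methoxy group at this position would stay level with compound 3 or fall back towards compound 1.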